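The source may hold more compounds than are shown below. What is called first, only, known or untested is meant among the compounds shown, and "the series" means these compounds.

Measured so far:

compound 1 `O=C1NCCN1c1ccc(S(=O)(=O)Nc2ccc(F)c(F)c2)cc1`: 620 nM
compound 2 `O=C1NCCN1c1ccc(S(=O)(=O)Nc2ccc(C3CCCCC3)cc2)cc1`: > 1000 nM
compound 3 `O=C1NCCN1c1ccc(S(=O)(=O)Nc2cccc(Oc3ccccc3)c2)cc1`: 220 nM

These three compounds share one core and differ only in the ring carried on the sulfonamide nitrogen. In a functional assay on MCF7 cells (Homo sapiens) for antiproliferative activity, read by sulforhodamine B assay, with a stated time of 48 h (a lower number here means a stronger inhibitor, a higher number a weaker inhibitor), compound 1 gives 620 nM. Compound 3 gives 220 nM in this assay, which is the lower of the two numbers, so compound 1 stands as the higher, and the gap between the two lies beyond the usual scatter. For compound 2 this assay reports only a limit, > 1000 nM, and not a number (the limit of > 1000 nM in this assay, at which 1 of the 3 values shown sits).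

Compound 4 `Cc1ccc(NS(=O)(=O)c2ccc(N3CCNC3=O)cc2)c(C)c1` has not yet been measured. It differs from compound 1 in one place: 2,4-dimethylphenyl in place of 3,4-difluorophenyl on a sulfonamide nitrogen. For the measured compounds named here, no measured pair here shows exactly this kind of change, so there is no direct step to lean on. The two rings are of the same size and carry no donor or acceptor, so the step from compound 1 to compound 4 is expected to be small, a 1.1-fold higher number from compound 1 to compound 4 (0.05 log units; within the scatter), with no clear direction beyond the scatter. Compound 4 is therefore estimated at 700 nM, within 250 nM to 2000 nM.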

Compound 4, half-maximal inhibitory concentration: 230 nM
Beside the measured number, compound 4's estimate is 3.0-fold (0.48 log units) above it, outside the stated range (below it).
By their numbers in this assay, from the lowest: compounds 3 and 4 (each within the scatter of the next); then compound 1. At a limit, above all of these: compound 2.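

In this assay, placing 2,4-dimethylphenyl where 3,4-difluorophenyl stood on a sulfonamide nitrogen gives a 2.7-fold lower number from compound 1 to compound 4 (0.43 log units; beyond the scatter). This position therefore responds to a change in the groups on the ring, even with the aromatic ring itself kept. The two groups match in heavy atom count, in ring type and in carrying no hydrogen-bond donors or acceptors, so these counts alone do not foretell the number, and nothing shown here explains the direction of the step.

The methyl groups arrive and the fluorines leave in one change, and this single pair cannot tell how much of the step belongs to each. On these data alone, what an amine or a carboxylic acid on this ring would do to the number remains open.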